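Adding a Hydroxymethyl to the Oxadiazole of Compound 3

This account rests on a few compounds, and the source may have more. Where it says the series, first, only, none or still open, it means among the compounds named here.

In an assay on microsomes from liver (strain Wistar) for inhibition of acyl-CoA desaturase 1 (Rattus norvegicus), read by HPLC, with stated times of 1 h and 60 min (a higher number here means a weaker inhibitor, a lower number a stronger inhibitor), compound 3 `FC(F)(F)c1ccccc1OC1CCN(c2ncc(-c3ncon3)s2)CC1` gives 4 nM. Compound 1 `NC(=O)c1cnc(N2CCC(Oc3ccccc3C(F)(F)F)CC2)s1` gives 3 nM, and the step of a 1.3-fold higher number from compound 1 to compound 3 (0.12 log units; within the scatter) separates the two. Compound 2 `Cc1nnc(-c2cnc(N3CCC(Oc4ccccc4C(F)(F)F)CC3)s2)s1` gives 750 nM, the furthest from compound 3, as the step of a 190-fold lower number from compound 2 to compound 3 (2.27 log units; beyond the scatter) shows. Compound 4 `OCc1nc(-c2cnc(N3CCC(Oc4ccccc4C(F)(F)F)CC3)s2)no1` differs from compound 3 by hydroxymethyl in place of hydrogen on an aromatic carbon. Within the data shown here, none of the measured steps changes a substituent on that five-membered ring: the steps of a 250-fold higher number from compound 1 to compound 2 (2.40 log units; beyond the scatter) and a 1.3-fold higher number from compound 1 to compound 3 (0.12 log units; within the scatter) each swap the whole group attached to the shared core. Among the measured compounds shown here, with no direct precedent, the step of a 1.5-fold higher number from compound 3 to compound 4 (0.18 log units; within the scatter) is expected to stay within the scatter. Compound 4 is therefore estimated at 6 nM, with a range from 2 nM to 25 nM.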

Compound 4, half-maximal inhibitory concentration: 1 nM
For compound 4 the middle estimate is 6.0-fold (0.78 log units) above the measured one, and the stated range ends above it.
By their numbers in this assay, from the lowest: compound 4; then compounds 1 and 3 (each within the scatter of the next); then compound 2.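

In this assay, hydroxymethyl in place of hydrogen on the aromatic carbon next to the ring oxygen gives a 4.0-fold lower number from compound 3 to compound 4 (0.60 log units; beyond the scatter), the only step shown that adds a substituent to this five-membered ring rather than swapping the whole group. The 5-(hydroxymethyl)-1,2,4-oxadiazol-3-yl group also stands apart from carbamoyl, with a 3.0-fold lower number from compound 1 to compound 4 (0.48 log units; beyond the scatter), and from 5-methyl-1,3,4-thiadiazol-2-yl, with a 750-fold lower number from compound 2 to compound 4 (2.88 log units; beyond the scatter). Nothing measured here explains these steps. Open, from the compounds shown here alone, is whether the hydroxymethyl oxygen matters or the added carbon alone, which a methyl or methoxymethyl on that carbon would show. Also open, going by these compounds, is how an aminomethyl or a longer chain such as hydroxyethyl would read.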